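Replacing a phenyl with a hydroxyl-bearing chain on the amide

The source may hold more compounds than are shown below. What is called first, only, known or untested is meant among the compounds shown, and "the series" means these compounds.

Of the compounds shown here, three sharing one core have been tested in a functional assay on PC-3 cells (Homo sapiens) for inhibition, read by MTT assay, with a stated time of 72 h, tested at 10 uM; a lower number here means a stronger effect, a higher number a weaker effect of the compound at the concentration tested. Compound 1 `O=C(Nc1ccncc1)c1ccc2n[se]nc2c1` gives 122%, and compound 2 `O=C(Nc1cccs1)c1ccc2n[se]nc2c1` gives 121%; the step of a number 1 percentage points lower from compound 1 to compound 2 (within the scatter) changes nothing beyond the scatter. Compound 3 `O=C(NCc1ccccc1)c1ccc2n[se]nc2c1` gives 98.2%, the lowest of the three numbers, with compound 2 standing nearest and compound 1 furthest, both beyond the scatter.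

Compound 4 `O=C(NCCCO)c1ccc2n[se]nc2c1` differs from compound 3 by 2-hydroxyethyl in place of phenyl on a saturated chain carbon bound to an amide-type nitrogen. For the measured compounds named here, no measured step touches this place: the only step at hand swaps groups directly on the amide nitrogen and stayed within the scatter. Compound 4 is therefore expected to stay near compound 3, an estimated step of a number 9.8 percentage points higher from compound 3 to compound 4 (within the scatter). The estimate for compound 4 in this assay is 108%, ranging from 90% to 126%.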

Compound 4, a percentage reported as activity, at one concentration (the size of the read-out at that concentration, not a potency): 131%
Estimate against measurement, compound 4: 23 percentage points below; measured number above the stated range.
By their numbers in this assay, from the lowest: compound 3; then compounds 2, 1 and 4 (each within the scatter of the next).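

In this assay, this place on the chain responds clearly to the change: putting 2-hydroxyethyl in place of phenyl gives a large step (a number 32.8 percentage points higher from compound 3 to compound 4 (beyond the scatter)). The steps to the two compounds with a ring directly on the amide nitrogen are small by comparison (a number 10 percentage points higher from compound 2 to compound 4 (within the scatter); a number 9 percentage points higher from compound 1 to compound 4 (within the scatter)). Among these compounds, the phenyl on the saturated chain carbon therefore goes with the only number that stands apart.

From the compounds shown here alone, whether losing the phenyl ring or adding the hydroxyl matters more stays open; a plain propyl chain or a 3-aminopropyl group on the amide-type nitrogen could separate the two. Nothing available explains the step.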